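Trading Isobutyl for Phenyl: A Step Expected to Be Small

A few compounds are considered here, and "the series" means these few. Any claim that something is new, unique, unknown or untested is made for them only; others in the source may bear on it.

Of the compounds shown here, three have so far been tested in a functional assay on PC-3 cells (Homo sapiens) for cytotoxicity, read by MTT assay, with a stated time of 72 h; on this read-out higher numbers stand for weaker inhibition of growth and lower numbers for stronger inhibition of growth. Compound 1 `CC(C)COC(=O)Nc1ccc([Se]C#N)cc1` gives 47300 nM. Compound 2 `N#C[Se]c1ccc(NC(=O)OCc2ccc([N+](=O)[O-])cc2)cc1` gives 36500 nM, and compound 3 `O=C(Nc1ccc([Se][Se]c2ccc(NC(=O)OCc3ccc([N+](=O)[O-])cc3)cc2)cc1)OCc1ccc([N+](=O)[O-])cc1` gives 27100 nM. These three numbers sit close together: the gap between compound 1 and compound 2, and the gap between compound 1 and compound 3, both fall within the usual scatter of repeated measurements, so on these data none of the three can be told apart from the others.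

Compound 4 `N#C[Se]c1ccc(NC(=O)Oc2ccccc2)cc1` has not yet been measured. It differs from compound 1 in a single place: phenyl in place of isobutyl on an oxygen next to a carbonyl group. For the measured compounds named here, no pair of measured compounds differs by this change alone, so there is no measured step of this kind to lean on. Given how tightly the three measured numbers cluster, the step from compound 1 to compound 4 is expected to stay within the scatter, with no clear direction: a 1.4-fold lower number from compound 1 to compound 4 (0.13 log units; within the scatter). Compound 4 is therefore estimated to give 35000 nM in this assay, with a likely range from 15000 nM to 80000 nM.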

Compound 4, concentration for total growth inhibition: 37500 nM
Estimate against measurement, compound 4: 1.1-fold (0.03 log units) below; the measured number falls inside the stated range.
By their numbers in this assay, from the lowest: compounds 3, 2, 4 and 1 (each within the scatter of the next).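

In this assay, for the compounds shown here, the exchange of isobutyl for phenyl on an oxygen next to a carbonyl group now gives the first step that can be read at this position: a 1.3-fold lower number from compound 1 to compound 4 (0.10 log units; within the scatter). The two groups differ visibly in their make-up, since isobutyl has no ring while phenyl is one six-membered aromatic ring of carbon only, yet this assay cannot tell the two compounds apart, so for this one pair the exchange leaves the read-out without a clear shift in either direction. Nothing at hand offers a measured reason for this outcome, so the step stands as an observation only.

The compounds shown leave open whether this flat picture holds for other kinds of group at the same place, such as a longer chain than isobutyl, an amine or a carboxylic acid, any of which might or might not give a step beyond the scatter. A single pair also cannot show whether the same exchange would give a similar step on another core or in another cell line.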